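Removing the Methyl from a Pyridine-Bearing Thiosemicarbazone

The source may report more compounds than this note shows. Statements on the series, on what has been measured and on what is new or still open speak of the compounds shown alone.

Compounds measured so far:
- Compound 1, `Cc1cccc(/C(N)=N/NC(=S)N2CCSCC2)n1`: 38.6%
- Compound 2, `Cc1ccnc(/C(N)=N/NC(=S)N2CCSCC2)c1`: 74.2%

Both compounds were tested in a functional assay on MCF7 cells (Homo sapiens) for cytotoxicity, read by MTT assay, with a stated time of 72 h, tested at 30 uM; a higher number here means more inhibition of growth at the concentration tested, a lower number less inhibition of growth. Of the two numbers seen so far, compound 2 stands highest, with 74.2%. Its nearest neighbour is compound 1, which gives 38.6%, a gap that lies beyond the usual scatter of this kind of measurement. For the measured compounds named here, the two compounds carry the same methyl group on different carbons of the same ring, and no step between them is computed, so the two values can only be set side by side.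

The next compound to consider is compound 3, `N/C(=N\NC(=S)N1CCSCC1)c1ccccn1`. It differs from compound 2 by a single change: hydrogen in place of methyl on an aromatic carbon. Going by the values given here, since no step between measured compounds has been computed, there is no direct guide to how the loss of this methyl will play out, and either direction is possible. The expectation here is a modest decrease, within or just beyond the scatter, giving a number 16.2 percentage points lower from compound 2 to compound 3 (beyond the scatter). Compound 3 is therefore estimated to reach 58%, with a range from 30% to 85%.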

Compound 3, percent growth inhibition at one concentration: 72.6%
Beside the measured number, compound 3's estimate is 14.6 percentage points below it, within the range that was stated.
By their numbers in this assay, from the lowest: compound 1; then compounds 3 and 2 (each within the scatter of the next).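

In this assay the methyl on the aromatic carbon opposite the ring nitrogen can give way to hydrogen with no change that stands out from the scatter (a number 1.6 percentage points lower from compound 2 to compound 3 (within the scatter)), so in this pair the methyl at this position adds nothing that can be detected. The same exchange tells a different story for the methyl on another carbon of the same ring, where the step is large and beyond the scatter (a number 34 percentage points higher from compound 1 to compound 3 (beyond the scatter)). Read together, the two steps show that the outcome of removing a methyl depends on which ring carbon carries it, and that the low number belongs to one placement rather than to methyl groups in general.

No supporting measurement explains why the two ring carbons behave so differently. The compounds shown also leave open whether the carbon opposite the ring nitrogen would tolerate something other than methyl or hydrogen, such as an amine, a methoxy group or a longer chain, and whether the same would hold at the carbon that carries the methyl in compound 1.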